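Swapping cyclopropylmethyl for pyridin-4-ylmethyl on a kinase-like scaffold

The compounds below may be only part of what the source reports. "The series", "measured", "known", "first", "only" and "open" are said of these compounds alone.

Measured compounds:
Compound 1, `Nc1nc(Cl)c(-c2ncco2)c(N[C@@H]2C[C@H](CO)[C@@H](O)[C@H]2O)n1`, gives > 25000 nM.
Compound 2, `Cc1nc(NCC2CC2)nc(N[C@@H]2C[C@H](CO)[C@@H](O)[C@H]2O)c1-c1nc2ccccc2s1`, gives 8000 nM.

Compound 1 was tested in an ADME assay on cells (Homo sapiens) for cytotoxicity, read by polymerase chain reaction, with a stated time of 3 days (on this read-out higher numbers stand for lower toxicity in this test and lower numbers for higher toxicity in this test), and returned > 25000 nM, which is a limit of the assay rather than a number; it is noted in the evidence as the limit of > 25000 nM in this assay, at which 1 of the 2 values shown sits. Among the compounds with values here, compound 2 gives 8000 nM in this assay, the only actual number among the two values shown.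

Compound 3, `Cc1nc(NCc2ccncc2)nc(N[C@@H]2C[C@H](CO)[C@@H](O)[C@H]2O)c1-c1nc2ccccc2s1`, is not yet measured. It differs from compound 2 in one place: pyridin-4-yl in place of cyclopropyl on a saturated chain carbon bound to a nitrogen on an aromatic ring.

Within the data shown here, no step between measured compounds is available to calibrate this change. The expectation for the step of a 1.5-fold higher number from compound 2 to compound 3 (0.18 log units; within the scatter) is therefore a small shift, if any, toward lower toxicity, not clearly beyond the scatter. Compound 3 is estimated at 12000 nM in this assay, with a range from 4000 nM to 30000 nM.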

Compound 3, half-maximal cytotoxic concentration: 7000 nM
Beside the measured number, compound 3's estimate is 1.7-fold (0.23 log units) above it; measured number inside the range.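

In this assay, putting pyridin-4-yl in place of cyclopropyl on a saturated chain carbon bound to a nitrogen on an aromatic ring gives a 1.1-fold lower number from compound 2 to compound 3 (0.06 log units; within the scatter). This is the first step shown that changes one place only, and it shows that this position takes a group of 6 heavy atoms instead of 3, with a hydrogen-bond acceptor added, without the read-out leaving the scatter. Nothing measured here bears on why the two compounds read alike.

The compounds shown leave open whether the ring nitrogen of pyridin-4-yl plays any part, since a plain phenyl ring in the same place would be needed to tell. They also leave open whether an amine, a carboxylic acid or a longer chain here would move the number in this assay beyond the scatter.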